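Moving the chlorine on the phenyl ring of a piperazine series

The source may report more compounds than this note shows. Statements on the series, on what has been measured and on what is new or still open speak of the compounds shown alone.

Measured compounds:
compound 1, `O=c1oc2cccnc2n1CN1CCN(c2cccc(Cl)c2)CC1`, 10.5 mg/kg
compound 2, `O=c1oc2cccnc2n1CN1CCN(c2ccccc2Cl)CC1`, 22.2 mg/kg

Compound 2 holds the highest of the two numbers in a functional assay on the whole organism with Mus musculus as the target; a higher number here means that more compound is needed for the effect, a lower number that less compound is needed; its nearest neighbour is compound 1, which stands a 2.1-fold higher number from compound 1 to compound 2 (0.33 log units; beyond the scatter) lower in this assay. Within the data shown here, the only measured step, a 2.1-fold higher number from compound 1 to compound 2 (0.33 log units; beyond the scatter), shows that moving the chlorine from 3-chlorophenyl to 2-chlorophenyl raises the dose by a modest amount, beyond the scatter.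

Compound 3, `O=c1oc2cccnc2n1CN1CCN(c2ccc(Cl)cc2)CC1`, differs from compound 2 by 4-chlorophenyl in place of 2-chlorophenyl on an amine nitrogen in a ring. Among the measured compounds shown here, no measured pair covers this exact exchange. For the measured compounds named here, the one known step shows that the position of the chlorine can move the dose by a modest amount, so a change of similar size in either direction is plausible. Taking the 3-chlorophenyl compound 1 as the closer precedent, compound 3 is expected to give 13 mg/kg in this assay, with a range of 5 mg/kg to 35 mg/kg, an estimated step of a 1.7-fold lower number from compound 2 to compound 3 (0.23 log units; within the scatter).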

Compound 3, dose for half-maximal effect: 10.6 mg/kg
Compound 3: middle estimate off by 1.2-fold (0.09 log units), on the high side; measured number inside the range.
By their numbers in this assay, from the lowest: compounds 1 and 3 (each within the scatter of the next); then compound 2.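

In this assay the 4-chlorophenyl group brings the dose back down, with a 2.1-fold lower number from compound 2 to compound 3 (0.32 log units; beyond the scatter), so the higher number of compound 2 is not shared by both other chlorine positions. Among these compounds, the step of a 1.0-fold higher number from compound 1 to compound 3 (0.00 log units; within the scatter) shows no difference between 3-chlorophenyl and 4-chlorophenyl, which leaves 2-chlorophenyl as the only one of these three groups that stands apart. No measurement shown here explains why this one chlorine position differs.

As far as these compounds go, what remains open is whether the chlorine is needed at all, since a plain phenyl ring would be the direct test. From the compounds shown here alone, it is also open whether a fluorine, a methyl or a methoxy group would follow the same order across these ring positions.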